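A few compounds are considered here, and "the series" means these few. Any claim that something is new, unique, unknown or untested is made for them only; others in the source may bear on it.

Measured so far:
- compound 1 `O=c1[nH]c2ccccc2cc1/C=N/Cc1ccccc1`: "not active" (no number reported)
- compound 2 `Cc1ccc2[nH]c(=O)c(/C=N/O)cc2c1`: 160000 nM
- compound 3 `O=c1[nH]c2ccccc2cc1/C=N/O`: 118000 nM

All three share one core and differ only in what hangs off it. In a functional assay, read by spectrophotometry, with a stated time of 30 min (a higher number here means a weaker inhibitor, a lower number a stronger inhibitor), compound 3 gives 118000 nM, the lower of the two numbers recorded, but its nearest neighbour is compound 2, and the step of a 1.4-fold lower number from compound 2 to compound 3 (0.13 log units; within the scatter) lies within the scatter, so the two cannot be told apart. Compounds 2 and 3 carry a hydroxy group; in its place compound 1 carries a benzyl group, and compound 1 is reported as "not active" (no number reported) in this assay, without a number.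

Compound 4 `N/N=C/c1cc2ccccc2[nH]c1=O` is the next step from compound 3: amino in place of hydroxy on a double-bonded nitrogen. For the measured compounds named here, no measured step matches this change. Going by the values given here, the single step available, a 1.4-fold lower number from compound 2 to compound 3 (0.13 log units; within the scatter), concerns a methyl on an aromatic carbon and says nothing about the group on the double-bonded nitrogen. Among the compounds with values here, the only hint is compound 1, where a larger replacement at that position gave "not active" (no number reported). An amino group is as small as a hydroxy group, so a step no larger than the scatter is expected, with some risk that activity is lost. The estimate for compound 4 is 150000 nM, in a range from 60000 nM to 400000 nM, which means an expected step of a 1.3-fold higher number from compound 3 to compound 4 (0.10 log units; within the scatter).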

Compound 4, half-maximal inhibitory concentration: 729000 nM
Compound 4: middle estimate off by 4.9-fold (0.69 log units), on the low side; measured number outside the range, above it.
By their numbers in this assay, from the lowest: compounds 3 and 2 (each within the scatter of the next); then compound 4.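

In this assay the position on the double-bonded nitrogen now has a size attached to it: amino in place of hydroxy gives a 6.2-fold higher number from compound 3 to compound 4 (0.79 log units; beyond the scatter) and so moves the number beyond the scatter. Earlier, this position offered only the benzyl group of compound 1, which gave no number and so could not show how much a change here costs; this step shows that even an exchange of one heavy atom for another matters, although the counts of hydrogen-bond donors and acceptors stay the same. Compound 4 still gives a number, so activity in this series survives the loss of hydroxy, and no measurement shown explains why the two groups differ.

Both replacements of hydroxy shown, amino in compound 4 and benzyl in compound 1, lead away from the lower numbers, but two groups cannot show whether any group here could match or beat hydroxy. Going by these compounds, a methoxy group or a short alkyl chain on the double-bonded nitrogen would test whether the hydrogen on the oxygen of hydroxy is what matters, and that question remains open.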